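Swapping a Saturated Ring for a Small Aromatic Ring

A few compounds are considered here, and "the series" means these few. Any claim that something is new, unique, unknown or untested is made for them only; others in the source may bear on it.

Compounds measured so far:
compound 1, `CC(=O)N1CCCC([C@@H]2[C@@H](C(=O)Nc3ccc(F)c(C#N)c3)c3ccccc3C(=O)N2CC(C)C)C1`, 69000 nM
compound 2, `CC(C)CN1C(=O)c2ccccc2[C@H](C(=O)Nc2ccc(F)c(C#N)c2)[C@H]1c1ccsc1`, < 1000 nM
compound 3, `CC(C)CN1C(=O)c2ccccc2[C@H](C(=O)Nc2ccc(F)c(C#N)c2)[C@H]1c1cccnc1`, 55000 nM

All three share one core and differ only in the group on a saturated ring carbon. In a physicochemical assay for solubility, in phosphate buffer, with a stated time of 18 h, at pH 7 (a higher number here means a more soluble compound, a lower number a less soluble compound), compound 1 gives 69000 nM. Compound 3 sits beside it, since a 1.3-fold lower number from compound 1 to compound 3 (0.10 log units; within the scatter). Compound 2 reaches only a limit of this assay, (the limit of < 1000 nM in this assay, at which 1 of the 3 values shown sits), so it has no number of its own. The two measured steps thus split sharply: an at least 69-fold lower number from compound 1 to compound 2 (1.83 log units; beyond the scatter), whereas a 1.3-fold lower number from compound 1 to compound 3 (0.10 log units; within the scatter).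

Compound 4, `CC(C)CN1C(=O)c2ccccc2[C@H](C(=O)Nc2ccc(F)c(C#N)c2)[C@H]1c1csnn1`, is not yet measured. It differs from compound 1 in this way: 1,2,3-thiadiazol-4-yl in place of 1-acetylpiperidin-3-yl on a saturated ring carbon. The thiophen-3-yl step shows that a five-membered sulfur-containing ring can cut the number hard, while the pyridin-3-yl step shows that a nitrogen-rich aromatic ring can leave it unchanged. The 1,2,3-thiadiazol-4-yl ring carries both features, so a moderate drop is expected, smaller than the thiophene step. Compound 4 is therefore estimated at 20000 nM, between 3000 nM and 70000 nM, meaning an expected 3.5-fold lower number from compound 1 to compound 4 (0.54 log units; beyond the scatter).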

Compound 4, solubility: 5000 nM
The estimate for compound 4 lay 4.0-fold (0.60 log units) above the measured number; the range from low to high includes it.
By their numbers in this assay, from the lowest: compound 4; then compounds 3 and 1 (each within the scatter of the next). At a limit, below all of these: compound 2.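

In this assay, the aromatic groups at this saturated ring carbon no longer split into just two levels. Compound 4 sits apart from both higher values: a 14-fold lower number from compound 1 to compound 4 (1.14 log units; beyond the scatter) and an 11-fold lower number from compound 3 to compound 4 (1.04 log units; beyond the scatter). Nitrogen in an aromatic ring is therefore not enough to keep the number high, since 1,2,3-thiadiazol-4-yl carries ring nitrogen and still falls well short of pyridin-3-yl. A sulfur-containing five-membered aromatic ring also need not give the lowest reading, as the step from thiophen-3-yl shows: an at least 5.0-fold higher number from compound 2 to compound 4 (0.69 log units; beyond the scatter).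

The true size of that last step stays open, as compound 2 has only a limit: the limit of < 1000 nM in this assay, at which 1 of the 4 values shown sits.

Also open is how an amine, a carboxylic acid or an oxadiazole at this carbon would compare, and the compounds shown do not explain the drop at compound 4.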